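A few compounds are considered here, and "the series" means these few. Any claim that something is new, unique, unknown or untested is made for them only; others in the source may bear on it.

- compound 1 `O=c1cc(I)n([C@@H]2O[C@H](CO)[C@@H](O)[C@H]2O)c(=O)[nH]1`: 15300 nM
- compound 2 `O=c1cc(NO)n([C@@H]2O[C@H](CO)[C@@H](O)[C@H]2O)c(=O)[nH]1`: > 50000 nM

Among the compounds with values here, in a functional assay on ML1 cells (Homo sapiens) for antiproliferative activity, read by WST assay, with a stated time of 3 days (on this read-out lower numbers stand for stronger inhibition and higher numbers for weaker inhibition), compound 1 gives 15300 nM, the only exact number so far. The entry for compound 2 is > 50000 nM, a limit of the assay rather than a number. Compound 3 `O=c1[nH]c(=O)n([C@@H]2O[C@H](CO)[C@@H](O)[C@H]2O)c(I)c1F` keeps the iodo group and differs from compound 1 by fluoro in place of hydrogen on an aromatic carbon. Within the data shown here, the only measured step, an at least 3.2-fold higher number from compound 1 to compound 2 (0.51 log units; beyond the scatter), replaces the iodo group instead, so it says little about this change. No clear shift beyond the scatter is therefore expected, though the uncertainty is wide. The expected step is a 1.2-fold higher number from compound 1 to compound 3 (0.07 log units; within the scatter). Compound 3 is estimated at 18000 nM, within a range of 5000 nM to 50000 nM.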

Compound 3, half-maximal inhibitory concentration: > 50000 nM
Compound 3: a limit, no number; the forecaster's own chance of this, stated with the estimate: 25%; middle value at least 2.7-fold (0.44 log units) away from the limit.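

In this assay, within the data shown here, the earlier step showed only that the iodo group could not be swapped for hydroxyamino without a change; this one shows that the hydrogen ortho to the iodo group matters too, even for a substitution of a single fluoro: an at least 3.2-fold higher number from compound 1 to compound 3 (0.51 log units; beyond the scatter). As far as these compounds go, compound 3 gives > 50000 nM, a limit of the assay and not a number, so the true size of this weakening stays unknown. The read-out now tops out for much of this small set: the limit of > 50000 nM in this assay, at which 2 of the 3 values shown sit.

From the compounds shown here alone, whether a methyl group or an amine at this position would keep the activity of compound 1 remains open. Compound 2 and compound 3 also cannot be ranked against each other.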